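Swapping the aromatic group of compound 1

A few compounds are considered here, and "the series" means these few. Any claim that something is new, unique, unknown or untested is made for them only; others in the source may bear on it.

compound 1 `Cc1oc(-c2c(F)cccc2F)nc1CN1CCC(C(=O)NCCCN2C[C@H](C)C[C@H](C)C2)CC1`: 0.35 h
compound 2 `CC[C@@H]1C[C@H](CC)CN(CCCNC(=O)C2CCN(Cc3nc(-c4c(F)cccc4F)oc3C)CC2)C1`: 0.065 h
compound 3 `Cc1ccccc1-c1nc(CN2CCC(C(=O)NCCCCN3C[C@H](C)C[C@H](C)C3)CC2)c(C)o1`: 0.2 h

In an ADME assay on microsomes from liver (Rattus norvegicus) for metabolic stability, read by LC-MS, using NADPH, at 37 degrees C (on this read-out lower numbers stand for a shorter-lived compound and higher numbers for a longer-lived compound), compound 1 at 0.35 h lies within the scatter of compound 3 at 0.2 h and is the reference here. Among the measured compounds shown here, compound 4 `COc1cccc(Cl)c1-c1nc(CN2CCC(C(=O)NCCCN3C[C@H](C)C[C@H](C)C3)CC2)c(C)o1` carries 2-chloro-6-methoxyphenyl in place of 2,6-difluorophenyl on an aromatic carbon and no measured step covers that swap alone. For the measured compounds named here, the one measured step, a 5.4-fold lower number from compound 1 to compound 2 (0.73 log units; beyond the scatter), lies elsewhere on the molecule, so it bears only indirectly. Compound 3 differs from compound 1 in the aromatic group and the chain, yet stays within the scatter. The estimated step is a 1.8-fold lower number from compound 1 to compound 4 (0.24 log units; within the scatter) and is expected to stay within the scatter. For compound 4 the half-life in this assay is expected to be 0.2 h, with a range from 0.08 h to 0.5 h.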

Compound 4, half-life: 0.055 h
Compound 4: the middle estimate sits 3.6-fold (0.56 log units) above what was measured; the measured number lies below the stated range.
By their numbers in this assay, from the lowest: compounds 4 and 2 (each within the scatter of the next); then compounds 3 and 1 (each within the scatter of the next).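

In this assay, among the compounds shown here, the aromatic group on the five-membered ring proves not to be a neutral place for change: 2-chloro-6-methoxyphenyl in place of 2,6-difluorophenyl gives a 6.4-fold lower number from compound 1 to compound 4 (0.80 log units; beyond the scatter) and this is the first single change read at this position. The swap alters both substituents of the phenyl ring at once, so the step belongs to the pair and not to either group alone. Nothing measured here accounts for the shorter half-life.

Going by these compounds, whether the chlorine or the methoxy group carries the step remains open, and 2-chloro-6-fluorophenyl or 2-fluoro-6-methoxyphenyl would separate them. Also open, on these data alone, is whether the same step holds alongside 3,5-diethylpiperidin-1-yl.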